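Adding a methyl to the phenyl of compound 3

The compounds below may be only part of what the source reports. "The series", "measured", "known", "first", "only" and "open" are said of these compounds alone.

Values in a functional assay on HCT-116 cells (Homo sapiens) for inhibition, read by MTT assay, with a stated time of 72 h; a lower number here means a stronger inhibitor, a higher number a weaker inhibitor:
- Compound 1 `COc1cc2c(Oc3ccc(NC(=O)c4nn(-c5ccccc5C)cc(C)c4=O)cc3)ccnc2cc1OCC(=O)NO`: 9260 nM
- Compound 2 `COc1cc2c(Oc3ccc(NC(=O)c4nn(-c5ccccc5C)cc(C)c4=O)cc3)ccnc2cc1OCCCC(=O)NO`: 640 nM
- Compound 3 `COc1cc2c(Oc3ccc(NC(=O)c4nn(-c5ccccc5)cc(C)c4=O)cc3)ccnc2cc1OCCCCCCC(=O)NO`: 150 nM

Of the three measured compounds, compound 3 gives the lowest number, 150 nM, and its gaps to the other two lie beyond the scatter. Compound 4 `COc1cc2c(Oc3ccc(NC(=O)c4nn(-c5ccccc5C)cc(C)c4=O)cc3)ccnc2cc1OCCCCCCC(=O)NO` differs from compound 3 in one place, with methyl in place of hydrogen on an aromatic carbon. Phenyl thus becomes 2-methylphenyl, with the chain unchanged.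

Going by the values given here, no measured step isolates this change. Among the compounds with values here, the only single-place step, a 14-fold lower number from compound 1 to compound 2 (1.16 log units; beyond the scatter), lies in the chain and leaves the 2-methylphenyl group untouched, so it gives no size for the methyl. Compound 2 carries 2-methylphenyl and gives 640 nM, but its chain also differs from that of compound 3, so that pair cannot separate the methyl from the chain.

Compound 4 shares its chain with compound 3, which gives 150 nM, and the estimate therefore rests on that value. In this assay, no change beyond the scatter is expected, and the expected step is a 1.1-fold lower number from compound 3 to compound 4 (0.03 log units; within the scatter). For compound 4 the estimated value is 140 nM, with an expected range from 60 nM to 350 nM.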

Compound 4, half-maximal inhibitory concentration: 660 nM
Estimate against measurement, compound 4: 4.7-fold (0.67 log units) below; the measured number lies above the stated range.
By their numbers in this assay, from the lowest: compound 3; then compounds 2 and 4 (each within the scatter of the next); then compound 1.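

In this assay, the methyl on an aromatic carbon, ortho to a large group, can now be read on its own, and this single added carbon gives a 4.4-fold higher number from compound 3 to compound 4 (0.64 log units; beyond the scatter). With 2-methylphenyl held fixed, the chain can also be read across three members: the full change gives a 14-fold lower number from compound 1 to compound 4 (1.15 log units; beyond the scatter), whereas the last part of it gives a 1.0-fold higher number from compound 2 to compound 4 (0.01 log units; within the scatter), so among these compounds a chain beyond that of compound 2 shows no step beyond the scatter, and the advantage of compound 3 over compound 1 and compound 2 cannot be credited to its chain alone. No measurement shown here accounts for the effect of the methyl.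

Phenyl appears only with the chain of compound 3, so whether the methyl has a step of similar size on the shorter chains remains open. Also open, going by these compounds, is how this position responds to a group other than methyl, such as ethyl, chlorine or methoxy, and whether a longer chain on the 2-methylphenyl series would move the number at all.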